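Chloro to Trifluoromethyl: Expected Cytotoxicity of Compound 4

This account rests on a few compounds, and the source may have more. Where it says the series, first, only, none or still open, it means among the compounds named here.

Measured compounds:
compound 1 `CCCCCCCc1c(C)[nH]c2cc(OC)c(Cl)cc2c1=O`: "not determined" (no result reported)
compound 2 `COc1cc2[nH]c(C)c(-c3ccc(Oc4ccc(Cl)cc4)cc3)c(=O)c2cc1Cl`: > 10000 nM
compound 3 `COc1cc2[nH]c(C)c(-c3ccc(Oc4ccc(OC(F)(F)F)cc4)cn3)c(=O)c2cc1Cl`: > 10000 nM

In an ADME assay on HepG2 cells (Homo sapiens) for cytotoxicity, read by resazurin assay, with a stated time of 24 h (a lower number here means a stronger inhibitor, a higher number a weaker inhibitor), compound 2 gives > 10000 nM, which is a limit of the assay and not a number. Compound 3 gives > 10000 nM in this assay, again a limit rather than a number. For compound 1 the result in this assay reads "not determined" (no result reported). So compound 2 stands where two of the three results shown stand, at the limit of > 10000 nM in this assay, at which 2 of the 3 values shown sit, with the third result carrying no number at all. For the measured compounds named here, no pair of measured compounds differs in just one place, so no measured step is available to judge against.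

Compound 4 `COc1cc2[nH]c(C)c(-c3ccc(Oc4ccc(C(F)(F)F)cc4)cc3)c(=O)c2cc1Cl` differs from compound 2 by trifluoromethyl in place of chloro on an aromatic carbon. Going by the values given here, with no measured step to lean on, no change beyond the usual scatter is expected in this assay, and a further limit is the likeliest outcome. Compound 4 is therefore expected to give about 20000 nM in this assay, within 8000 nM to 60000 nM. The expected step that the limit leaves unreadable from compound 2 to compound 4 is estimated to stay within the scatter.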

Compound 4, half-maximal inhibitory concentration: > 10000 nM
Compound 4: a limit, no number; the forecaster's own chance of this, stated with the estimate: 85%; the middle value is on the limit's open side.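

For the compounds shown here, compound 2 and compound 4 each give a limit and not a number in this assay, so no step between them can be read. The compounds shown leave open what number either would reach in this assay, and so whether trifluoromethyl in place of chloro changes the result at all.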